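Methoxy for Methyl on the Urea Nitrogen of Compound 2

The source may hold more compounds than are shown below. What is called first, only, known or untested is meant among the compounds shown, and "the series" means these compounds.

Compound 1: `CC(=O)NCC(=O)N1CC[C@H](C(=O)N(C)Cc2cc(C(F)(F)F)cc(C(F)(F)F)c2)[C@@H](c2ccc(F)cc2C)C1`, 0.043 nM
Compound 2: `CNC(=O)N1CC[C@H](C(=O)N(C)Cc2cc(C(F)(F)F)cc(C(F)(F)F)c2)[C@@H](c2ccc(F)cc2C)C1`, 0.048 nM

Of the compounds shown here, two have been measured in an assay on IM-9 cells for displacement of a labelled ligand from Substance-P receptor (Homo sapiens), read by scintillation counting, with a stated time of 30 min; on this read-out higher numbers stand for weaker inhibition and lower numbers for stronger inhibition. Compound 1 gives 0.043 nM, and compound 2 gives 0.048 nM. Among the measured compounds shown here, compound 2 holds the higher of the two numbers, but the only measured step, a 1.1-fold higher number from compound 1 to compound 2 (0.05 log units; within the scatter), lies within the scatter, so the two values are not distinguished.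

Compound 3, `CONC(=O)N1CC[C@H](C(=O)N(C)Cc2cc(C(F)(F)F)cc(C(F)(F)F)c2)[C@@H](c2ccc(F)cc2C)C1`, differs from compound 2 in one place: methoxy in place of methyl on an amide-type nitrogen. For the measured compounds named here, no measured step touches this nitrogen directly; the one step that exists, a 1.1-fold higher number from compound 1 to compound 2 (0.05 log units; within the scatter), shows that a sizeable exchange on the carbonyl carbon of the same urea-type group left the number essentially unchanged. On that basis no step beyond the scatter is expected for compound 3 in this assay, and a 1.5-fold higher number from compound 2 to compound 3 (0.16 log units; within the scatter) is the expected size. Compound 3 is therefore estimated at 0.07 nM, with a range from 0.025 nM to 0.2 nM.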

Compound 3, half-maximal inhibitory concentration: 0.073 nM
For compound 3 the middle estimate is 1.0-fold (0.02 log units) below the measured one; low and high end bracket the measured number.
By their numbers in this assay, from the lowest: compounds 1, 2 and 3 (each within the scatter of the next).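

Among the compounds shown here, this is the only measured exchange on the amide-type nitrogen itself, and in this assay methoxy in place of methyl gives a 1.5-fold higher number from compound 2 to compound 3 (0.18 log units; within the scatter), so the added oxygen does not separate the two compounds. The wider exchange on the carbonyl carbon, methoxyamino in place of acetamidomethyl, gives a 1.7-fold higher number from compound 1 to compound 3 (0.23 log units; within the scatter), so all three compounds remain within the scatter of one another. No independent measurement is available to explain this result.

Going by these compounds, whether an amine, a carboxylic acid or a longer chain such as butoxy on the same nitrogen would also stay within the scatter of compound 2 remains open. All three compounds share the rest of their structure, so whether these exchanges would behave the same way on a different core cannot be read from them.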